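A few compounds are considered here, and "the series" means these few. Any claim that something is new, unique, unknown or untested is made for them only; others in the source may bear on it.

For the measured compounds named here, in a functional assay on HT-29 cells (Homo sapiens) for cytotoxicity, read by MTT assay, with a stated time of 72 h (on this read-out higher numbers stand for weaker inhibition and lower numbers for stronger inhibition), compound 1 `COc1ccc(NC(=O)CN2CCN(c3nnc(Cc4ccncc4)c4ccccc34)CC2)cc1OC` gives 40100 nM, the middle of the three numbers measured so far. Compound 2 `O=C(CN1CCN(c2nnc(Cc3ccncc3)c3ccccc23)CC1)Nc1ccc(Br)cc1` gives 1990 nM, well below that, and compound 3 `Cc1ccc(F)cc1NC(=O)CN1CCN(c2nnc(Cc3ccccc3)c3ccccc23)CC1` gives 171000 nM, the highest of the three.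

Compound 4 `O=C(CN1CCN(c2nnc(Cc3ccncc3)c3ccccc23)CC1)Nc1cccc(F)c1` has not yet been measured. It keeps the core of compound 1 and changes only the group on the amide-type nitrogen, with 3-fluorophenyl in place of 3,4-dimethoxyphenyl on an amide-type nitrogen.

Going by the values given here, one measured step bears directly on this change. Replacing the same 3,4-dimethoxyphenyl with 4-bromophenyl at that nitrogen gave a 20-fold lower number from compound 1 to compound 2 (1.30 log units; beyond the scatter), a large step. This is a single example, and 3-fluorophenyl is a different group from 4-bromophenyl, so the same direction is expected in this assay, but with a smaller size. The expected change is a 5.7-fold lower number from compound 1 to compound 4 (0.76 log units; beyond the scatter). Compound 4 is therefore estimated at 7000 nM, with an expected range of 1500 nM to 35000 nM.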

Compound 4, half-maximal inhibitory concentration: 6130 nM
For compound 4 the middle estimate is 1.1-fold (0.06 log units) above the measured one; measured number inside the range.
By their numbers in this assay, from the lowest: compound 2; then compound 4; then compound 1; then compound 3.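

In this assay, a second replacement of 3,4-dimethoxyphenyl on the amide-type nitrogen gives a 6.5-fold lower number from compound 1 to compound 4 (0.82 log units; beyond the scatter) and so also lowers the number, which shows that the earlier drop is not unique to 4-bromophenyl. The replacing groups are not interchangeable, however: 3-fluorophenyl in place of 4-bromophenyl gives a 3.1-fold higher number from compound 2 to compound 4 (0.49 log units; beyond the scatter) in this comparison, so the choice of group at this position still matters after the dimethoxy groups are gone. No measurement shown here explains the differences among these groups.

On these data alone, compound 2 and compound 4 differ in both the halogen and its numbered place on the ring, so the effect of each alone remains unknown. As far as these compounds go, the effect of an amine or a carboxylic acid on this aromatic ring also remains open.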